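Trimming the Ammonium Substituent of a Betaine Analogue

This account rests on a few compounds, and the source may have more. Where it says the series, first, only, none or still open, it means among the compounds named here.

The two measured compounds share a carboxylate-bearing chain on a quaternary ammonium nitrogen. Compound 1 `C[N+](C)(CCCC(=O)[O-])CC1CC1` carries a cyclopropylmethyl group on that nitrogen, while compound 2 `C[N+]1(CCCC(=O)O)CCCC1` closes the nitrogen into a ring. In an assay for inhibition of gamma-butyrobetaine dioxygenase (Homo sapiens), read by HPLC, with stated times of 15 min and 30 min (a lower number here means a stronger inhibitor, a higher number a weaker inhibitor), compound 2 gives 490 nM. Compound 1 stands apart: in this assay compound 1 gives only a limit, > 1000000 nM, so no number is known for it. Of the two values shown, one sits at the limit of > 1000000 nM in this assay, at which 1 of the 2 values shown sits. Compound 3 `C=C[N+](C)(C)CCCC(=O)[O-]` has not yet been measured. It differs from compound 1 in one place, (vinyl in place of cyclopropylmethyl on an amine nitrogen). Going by the values given here, no step between measured compounds is given, so the size of the step in this assay must be guessed rather than read off. As compound 1 sits at the limit, any reported number for compound 3 would already be a gain. Compound 3 is expected to land at 20000 nM, with a range from 2000 nM to 200000 nM. That estimate means a step of an at least 50-fold lower number from compound 1 to compound 3 (1.69 log units; beyond the scatter) in this assay, expected toward a stronger inhibitor, though a limit again remains possible.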

Compound 3, half-maximal inhibitory concentration: 127000 nM
The estimate for compound 3 lay 6.4-fold (0.80 log units) below the measured number, and the stated range covers the measured number.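

Putting vinyl in place of cyclopropylmethyl on the amine nitrogen gives, in this assay, an at least 7.8-fold lower number from compound 1 to compound 3 (0.89 log units; beyond the scatter), the first sign that the read-out at this position responds to the group it carries. Going by these compounds alone, the single change removes the three-membered ring, shortens the substituent from 4 heavy atoms to 2 and brings in a double bond, all at once, and the one step does not tell these apart. As far as these compounds go, the true size of the step remains unknown because compound 1 has no number, only a limit: the limit of > 1000000 nM in this assay, at which 1 of the 3 values shown sits.

The compounds shown leave open whether a saturated ethyl group or a plain methyl group on the same nitrogen would match vinyl, which would show whether the double bond itself counts or only the shorter substituent. They also leave open whether a cyclopropyl group bonded directly to that nitrogen would restore or lose activity in this assay, and so whether the three-membered ring or the length of the substituent accounts for the gap.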